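The source may hold more compounds than are shown below. What is called first, only, known or untested is meant among the compounds shown, and "the series" means these compounds.

Compound 1, `CCOc1cccc(C2=NN(C(=O)OC)C(c3cc(OC)c(OC)c(OC)c3)C2)c1`, 4970 nM. Compound 2, `COC(=O)N1N=C(c2cccc(Cl)c2)CC1c1cc(OC)c(OC)c(OC)c1`, 160 nM.

Of the compounds shown here, two sharing one core have so far been measured in a functional assay on HeLa cells (Homo sapiens) for antiproliferative activity, read by MTT assay, with a stated time of 48 h; a higher number here means a weaker inhibitor of growth, a lower number a stronger inhibitor of growth. Compound 2 gives 160 nM, the lowest of the two numbers. For the measured compounds named here, its only neighbour, compound 1, gives 4970 nM, and a 31-fold lower number from compound 1 to compound 2 (1.49 log units; beyond the scatter). The unmeasured compound 3, `COC(=O)N1N=C(c2ccc(OC)c(OC)c2)CC1c1cc(OC)c(OC)c(OC)c1`, differs from compound 2 in one place: 3,4-dimethoxyphenyl in place of 3-chlorophenyl on a carbon with a double bond to nitrogen. Going by the values given here, the single measured step, a 31-fold lower number from compound 1 to compound 2 (1.49 log units; beyond the scatter), is the one that bears on this change; it shows that the ring carrying ethoxy in compound 1 comes with a far higher number than the ring carrying chloro in compound 2. Among the compounds with values here, compound 3 again carries alkoxy groups, two methoxy groups, where compound 2 carries chloro, so a step in the same direction as that from compound 2 back toward compound 1 is expected, of a size beyond the scatter but with no measured example of a dimethoxy ring to fix it. Compound 3 is therefore expected to give 2000 nM, within 500 nM to 8000 nM, which is expected to mean a 13-fold higher number from compound 2 to compound 3 (1.10 log units; beyond the scatter).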

Compound 3, concentration for 50% growth inhibition: 3390 nM
Compound 3: the middle estimate sits 1.7-fold (0.23 log units) below what was measured, within the range that was stated.
By their numbers in this assay, from the lowest: compound 2; then compounds 3 and 1 (each within the scatter of the next).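

In this assay, 3,4-dimethoxyphenyl in place of 3-chlorophenyl on the carbon with a double bond to nitrogen gives a 21-fold higher number from compound 2 to compound 3 (1.33 log units; beyond the scatter) and so shows that the large gap seen earlier is not confined to the ethoxy ring: among these three compounds, both rings that carry alkoxy groups stand apart from the chlorinated ring, and no compound goes against this. The change from the ethoxy ring to the dimethoxy ring gives a 1.5-fold lower number from compound 1 to compound 3 (0.17 log units; within the scatter) and thus separates compound 1 and compound 3 by no more than the usual scatter, so the added and shifted alkoxy substitution makes no readable difference at this position. No measurement is at hand that accounts for the standing of the chlorinated ring.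

The compounds shown leave open whether chloro is special at this position or whether other groups would serve as well, as 3-bromophenyl, 3-methylphenyl or 3,4-dichlorophenyl could tell. They also leave open how an amine or a carboxylic acid on this ring would fare, and whether the step holds when the methoxycarbonyl group on the shared core is replaced.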